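The compounds below may be only part of what the source reports. "The series", "measured", "known", "first", "only" and "open" are said of these compounds alone.

Compound 1 `CCCn1cc(-c2cnc(NCc3ccc4sccc4c3)c(C(=O)NCC3COc4ccccc4O3)c2)cn1` — in an assay on isolated protein for binding affinity to growth hormone secretagogue receptor type 1 (Homo sapiens) (a higher number here means a weaker inhibitor, a lower number a stronger inhibitor), compound 1 gives 84 nM.
Compound 2 `CCCn1cc(-c2cnc(NCc3ccc4occc4c3)c(C(=O)NCC3COc4ccccc4O3)c2)cn1` — compound 2 gives 150 nM.
Compound 3 `CCCn1cc(-c2cnc(NCc3ccc4ncsc4c3)c(C(=O)NCC3COc4ccccc4O3)c2)cn1` — compound 3 gives 260 nM.

All three share one core and differ only in the two-ring group attached on a saturated chain carbon bound to a nitrogen on an aromatic ring. Compound 3 stands at the highest number of the three: its nearest neighbour is compound 2, a 1.7-fold higher number from compound 2 to compound 3 (0.24 log units; within the scatter), and its furthest is compound 1, a 3.1-fold higher number from compound 1 to compound 3 (0.49 log units; beyond the scatter).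

Compound 4 `CCCn1cc(-c2cnc(NCc3ccc4c(c3)OCC4)c(C(=O)NCC3COc4ccccc4O3)c2)cn1` has not yet been measured. It differs from compound 3 in one place: a group of 9 heavy atoms (8 carbon, 1 oxygen; one five-membered non-aromatic ring with 1 hetero atom, one six-membered aromatic ring of carbon only) in place of a group of 9 heavy atoms (7 carbon, 1 nitrogen, 1 sulfur; one five-membered aromatic ring with 2 hetero atoms, one six-membered aromatic ring of carbon only), on a saturated chain carbon bound to a nitrogen on an aromatic ring. The measured steps that bear on this are the exchanges of one two-ring group for another at the same place: a 1.8-fold higher number from compound 1 to compound 2 (0.25 log units; within the scatter), a 1.7-fold higher number from compound 2 to compound 3 (0.24 log units; within the scatter) and a 3.1-fold higher number from compound 1 to compound 3 (0.49 log units; beyond the scatter). Together they show that such exchanges move the number by small to modest amounts only. Going by the values given here, no measured compound carries a non-aromatic five-membered ring, so the direction rests on thin ground. The step of a 1.5-fold lower number from compound 3 to compound 4 (0.18 log units; within the scatter) is expected to stay within the usual scatter. The estimate for compound 4 is 170 nM, with a range from 70 nM to 420 nM.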

Compound 4, half-maximal inhibitory concentration: 11 nM
For compound 4 the middle estimate is 15-fold (1.19 log units) above the measured one; measured number below the stated range.
By their numbers in this assay, from the lowest: compound 4; then compounds 1, 2 and 3 (each within the scatter of the next, the first and the last beyond it).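

Exchanging the two-ring group at this place can matter much more than compounds 1 to 3 suggested: in this assay the new group gives a 24-fold lower number from compound 3 to compound 4 (1.37 log units; beyond the scatter) and a 14-fold lower number from compound 2 to compound 4 (1.13 log units; beyond the scatter) and a 7.6-fold lower number from compound 1 to compound 4 (0.88 log units; beyond the scatter), which makes compound 4 the strongest inhibitor of the four. Going by these compounds alone, all three steps are larger than any seen among the earlier compounds, so those small differences did not mark the limit of what this position can do. The comparison with compound 2 is the most telling, since both groups have the same atom counts, yet one has an aromatic five-membered ring and the other a non-aromatic one. The data shown offer no explanation for this gain.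

With a single compound carrying a non-aromatic five-membered ring, it remains unclear whether that ring alone accounts for the step or whether another difference between the two groups contributes. A version with nitrogen in place of the ring oxygen, a six-membered ring holding one oxygen, or a single benzene ring bearing a methoxy group could help separate these possibilities.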